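A few compounds are considered here, and "the series" means these few. Any claim that something is new, unique, unknown or untested is made for them only; others in the source may bear on it.

Working notes on the series. The shared core carries a varied aryl group on a double-bonded chain carbon; compound 1 is `O=C1/C(=C\c2ccc(F)cc2)c2ccccc2N1c1c(Cl)cccc1Cl`, and in a functional assay on MOLT-4 cells (Homo sapiens) for cytotoxicity, read by MTT assay, with a stated time of 72 h (a lower number here means that less compound is needed, a higher number that more compound is needed for the effect), compound 1 gives "not determined" (no result reported). Compound 2 is `O=C1/C(=C\c2ccc(O)cc2)c2ccccc2N1c1c(Cl)cccc1Cl`, and in this assay compound 2 gives "not determined" (no result reported); for neither of these two has a number been returned. Within the data shown here, compound 3, `O=C1/C(=C\c2cccc(Br)c2)c2ccccc2N1c1c(Cl)cccc1Cl`, is the one member with a result: in this assay compound 3 gives 7 ug/mL. Among the measured compounds shown here, as the only number in hand, compound 3 cannot be placed relative to any other compound; it simply sets the level from which the next step is judged.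

Compound 4 is `O=C1/C(=C\c2ccccc2Cl)c2ccccc2N1c1c(Cl)cccc1Cl`. The change from compound 3 is 2-chlorophenyl in place of 3-bromophenyl on a double-bonded chain carbon bound to a double-bonded ring carbon. For the measured compounds named here, no measured pair in the set shows what such a change does in this assay, so the expectation rests on compound 3 alone. One halogenated phenyl replaces another of the same size, and a step of about the usual scatter is expected in this assay, with no clear direction; the expected step is a 1.1-fold higher number from compound 3 to compound 4 (0.06 log units; within the scatter). On that basis compound 4 is estimated at 8 ug/mL in this assay, in a range from 3.5 ug/mL to 18 ug/mL.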

Compound 4, concentration for half-maximal effect: 7 ug/mL
For compound 4 the middle estimate is 1.1-fold (0.06 log units) above the measured one; the measured number falls inside the stated range.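

In this assay, 2-chlorophenyl in place of 3-bromophenyl on a double-bonded chain carbon bound to a double-bonded ring carbon gives no change at the digits printed from compound 3 to compound 4 (within the scatter) for this pair. Among these compounds, this is the first step that can be read at this position, and it shows that two halogenated phenyl groups with different halogens and different substitution patterns can share the same printed number here, although the pair does not separate the halogen from its place on the ring. Nothing measured here explains this result.

Steps involving compound 1 and compound 2 cannot be read. As far as these compounds go, whether a phenyl group carrying an amine or a carboxylic acid, or a longer chain in place of the phenyl group, would stay at this level remains open.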